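Three sulfonamides at the assay limit, and a fourth

This account rests on a few compounds, and the source may have more. Where it says the series, first, only, none or still open, it means among the compounds named here.

Compound 1 `O=S(=O)(Nc1ccc(-c2nc3ccccc3o2)cc1)c1cccc(F)c1`: > 63000 nM
Compound 2 `Cc1ccc(S(=O)(=O)Nc2ccc3oc(-c4ccccc4)nc3c2)cc1`: > 63000 nM
Compound 3 `O=S(=O)(Nc1ccc(-c2nc3ccccc3o2)cc1)c1ccccc1Cl`: > 63000 nM

Each of these three values in an assay on isolated protein for inhibition of malate dehydrogenase, mitochondrial (Sus scrofa), with stated times of 45 min and 30 min (on this read-out lower numbers stand for stronger inhibition and higher numbers for weaker inhibition), is a limit of the assay rather than a number. Compound 2, whose structure is the starting point here, stands only at such a limit, and so do the other two. Among the measured compounds shown here, the one step between measured compounds that differ in a single place, from compound 1 to compound 3, is a step that the two limits leave unreadable from compound 1 to compound 3; with both ends at a limit, its size cannot be read. The picture is summed up by the limit of > 63000 nM in this assay, at which 3 of the 3 values shown sit.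

Compound 4 `O=S(=O)(Nc1ccc2oc(-c3ccccc3)nc2c1)c1cccc(F)c1` has not been measured. It differs from compound 2 in one place: 3-fluorophenyl in place of 4-methylphenyl on a sulfonyl sulfur. For the measured compounds named here, no measured step reports what this change does in this assay, because every value sits at the limit of > 63000 nM in this assay, at which 3 of the 3 values shown sit. The expectation can therefore rest only on the fact that all three measured compounds gave no number.

Compound 4 is estimated to sit around 100000 nM, in a range from 30000 nM to 400000 nM, most likely again reported only as a limit. The expected step from compound 2 is a step that the limit leaves unreadable from compound 2 to compound 4, which is no step beyond the scatter.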

Compound 4, half-maximal inhibitory concentration: > 63000 nM
Compound 4: only a limit was reported; the forecaster's own chance of this, stated with the estimate: 85%; the middle value is on the limit's open side.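

Compound 2 and compound 4 both stand only at a limit of the assay, so the swap of 4-methylphenyl for 3-fluorophenyl on the sulfonyl sulfur gives no step that can be read: the limit of > 63000 nM in this assay, at which 4 of the 4 values shown sit.

The compounds shown leave open whether any change to these sulfonamides would give an actual number in this assay, and how large its effect would be.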